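The source may hold more compounds than are shown below. What is called first, only, known or untested is meant among the compounds shown, and "the series" means these compounds.

Three amides built on one shared core have been measured. Compound 1 `Cc1ccccc1NC(=O)CCC(=O)OCCCCCCSc1ccc([N+](=O)[O-])c2nonc12` in an assay on isolated protein for inhibition of glutathione S-transferase P (Homo sapiens), with a stated time of 10 min (a higher number here means a weaker inhibitor, a lower number a stronger inhibitor), gives 4100 nM. Compound 2 `O=C(CCC(=O)OCCCCCCSc1ccc([N+](=O)[O-])c2nonc12)Nc1cccc(Cl)c1` in this assay gives 28800 nM. Compound 3 `O=C(CCC(=O)OCCCCCCSc1ccc([N+](=O)[O-])c2nonc12)Nc1ccc(F)cc1` in this assay gives 8570 nM, the second highest of the three numbers; the steps of a 2.1-fold higher number from compound 1 to compound 3 (0.32 log units; beyond the scatter) and a 3.4-fold lower number from compound 2 to compound 3 (0.53 log units; beyond the scatter) set it between the other two. Compound 4 `O=C(CCC(=O)OCCCCCCSc1ccc([N+](=O)[O-])c2nonc12)Nc1ccc(Br)cc1` differs from compound 3 by bromo in place of fluoro on an aromatic carbon. Among the measured compounds shown here, no measured step swaps one halogen for another at a fixed place: the steps of a 7.0-fold higher number from compound 1 to compound 2 (0.85 log units; beyond the scatter), a 2.1-fold higher number from compound 1 to compound 3 (0.32 log units; beyond the scatter) and a 3.4-fold lower number from compound 2 to compound 3 (0.53 log units; beyond the scatter) each alter both the identity and the place of the phenyl substituent, and all are modest. For compound 4 in this assay a step of a 1.2-fold lower number from compound 3 to compound 4 (0.09 log units; within the scatter) is therefore expected, within the scatter. Compound 4 is estimated at 7000 nM, between 2500 nM and 20000 nM.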

Compound 4, half-maximal inhibitory concentration: 5090 nM
Beside the measured number, compound 4's estimate is 1.4-fold (0.14 log units) above it; the measured number falls inside the stated range.
By their numbers in this assay, from the lowest: compounds 1, 4 and 3 (each within the scatter of the next, the first and the last beyond it); then compound 2.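

In this assay, the step that changes only the halogen, at the same place para to a large group, is a 1.7-fold lower number from compound 3 to compound 4 (0.23 log units; within the scatter), so bromo and fluoro are not told apart there. The 4-bromophenyl amide is likewise not separated from the 2-methylphenyl amide, a 1.2-fold higher number from compound 1 to compound 4 (0.09 log units; within the scatter), while the 3-chlorophenyl amide stands apart, a 5.7-fold lower number from compound 2 to compound 4 (0.75 log units; beyond the scatter), a step that alters both halogen and place. No available evidence bears on these numbers.

Still open, as far as these compounds go, is whether 3-bromophenyl would match 3-chlorophenyl, which would tie that gap to the place rather than the halogen. Also open, from the compounds shown here alone, is whether an amine or a carboxylic acid at the para place would move the number beyond the scatter.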